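The compounds below may be only part of what the source reports. "The series", "measured", "known", "first", "only" and "open" are said of these compounds alone.

Measured so far in a functional assay on MCF7 cells (Homo sapiens) for inhibition; a higher number here means a weaker inhibitor, a lower number a stronger inhibitor:
Compound 1, `CCn1c(=O)/c(=C2\Sc3ccc(C)cc3N2C)s/c1=C\c1ccncc1Nc1ccccc1Cl`: 650 nM
Compound 2, `CCn1c(=O)/c(=C2\Sc3ccc(C)cc3N2C)s/c1=C\c1ccncc1Nc1ccccc1C`: 400 nM
Compound 3, `CCn1c(=O)/c(=C2\Sc3cc(F)ccc3N2C)s/c1=C\c1ccncc1Nc1ccccc1C`: 1300 nM

The change from compound 2 to compound 1 is chloro in place of methyl on an aromatic carbon and it brought a 1.6-fold higher number from compound 2 to compound 1 (0.21 log units; within the scatter). Within the data shown here, compound 3 carries a different core; the difference between the cores of compound 2 and compound 3 is not broken down here, and compound 3 stands highest of the three numbers so far. Compound 4, `CCn1c(=O)/c(=C2\Sc3cc(F)ccc3N2C)s/c1=C\c1ccncc1Nc1ccccc1Cl`, has not been measured. It relates to compound 3 as compound 1 relates to compound 2: the change is chloro in place of methyl on an aromatic carbon, the same kind of change at the same described place. Because the earlier step of a 1.6-fold higher number from compound 2 to compound 1 (0.21 log units; within the scatter) stayed within the scatter, a step of similar size is expected from compound 3 to compound 4, namely a 1.6-fold higher number from compound 3 to compound 4 (0.21 log units; within the scatter). Compound 4 is therefore estimated to give 2100 nM in this assay, plausibly between 1000 nM and 4500 nM.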

Compound 4, half-maximal inhibitory concentration: 1300 nM
For compound 4 the middle estimate is 1.6-fold (0.21 log units) above the measured one; the range from low to high includes it.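

In this assay, chloro in place of methyl on an aromatic carbon brought no change at the digits printed from compound 3 to compound 4 (within the scatter). Set beside the earlier step, the change carries from one core to the other with no gap that can be told from scatter: the same change on two cores in this assay, a 1.6-fold higher number (0.21 log units; within the scatter) from compound 2 to compound 1 and no change at the digits printed (within the scatter) from compound 3 to compound 4, 1.6-fold (0.21 log units) apart, within the scatter of two such steps This shows that swapping methyl for chloro made no readable difference on either of these two cores, but it does not show that the change has an effect of its own, or that the same would hold on a third core.

The compounds shown leave open what other groups would do in place of the methyl or chloro, such as a methoxy group, a nitrile or an amine. They also leave open whether any such group would move the number beyond the scatter on both cores alike.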